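Fluoro for bromo on the indole-bearing core

The compounds below may be only part of what the source reports. "The series", "measured", "known", "first", "only" and "open" are said of these compounds alone.

Compound 1 `COC(=O)[C@@]1(C)CCC=C2[C@@H]1CC[C@@H](C)[C@]2(C)Cc1c[nH]c2ccc(F)cc12` gives 6200 nM in a functional assay on A549 cells (Homo sapiens) for inhibition, read by sulforhodamine B assay, with a stated time of 48 h; on this read-out higher numbers stand for weaker inhibition of growth and lower numbers for stronger inhibition of growth.
Compound 2 `COC(=O)[C@@]1(C)CCC=C2[C@@H]1CC[C@@H](C)[C@]2(C)Cc1c(C)[nH]c2ccc(C)cc12` gives 26000 nM in this assay.
Compound 3 `COC(=O)[C@@]1(C)CCC=C2[C@@H]1CC[C@@H](C)[C@]2(C)Cc1c(C)[nH]c2ccc(Br)cc12` gives 15000 nM in this assay.

Among these three numbers, compound 3 holds the second highest value; its nearest neighbour is compound 2, and the gap between them is within the scatter, while compound 1 sits furthest away, at a lower number beyond the scatter. For the measured compounds named here, the step of a 1.7-fold lower number from compound 2 to compound 3 (0.24 log units; within the scatter) is the only one-place change measured here, and it stays within the scatter.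

Compound 4 `COC(=O)[C@@]1(C)CCC=C2[C@@H]1CC[C@@H](C)[C@]2(C)Cc1c(C)[nH]c2ccc(F)cc12` differs from compound 3 by fluoro in place of bromo on an aromatic carbon. Going by the values given here, no measured pair shows this fluoro-for-bromo exchange directly. Compound 1 carries fluoro at the same position but lacks the methyl on the indole, so its value cannot be read as a step to compound 4; it only shows that a fluoro-bearing member of this series can sit at the lower end of the numbers seen. Given that the one measured change at this position, from methyl to bromo, stayed within the scatter, a small step is expected. Compound 4 is estimated at 12000 nM, with a range from 5000 nM to 30000 nM, which means an expected step of a 1.3-fold lower number from compound 3 to compound 4 (0.10 log units; within the scatter).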

Compound 4, concentration for 50% growth inhibition: 15000 nM
The estimate for compound 4 lay 1.3-fold (0.10 log units) below the measured number, within the range that was stated.
By their numbers in this assay, from the lowest: compound 1; then compounds 3, 4 and 2 (each within the scatter of the next).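

In this assay, the position described as meta to a fused ring and para to a fused ring now carries three groups on the same background: fluoro in place of bromo gives no change at the digits printed from compound 3 to compound 4 (within the scatter) and fluoro in place of methyl gives a 1.7-fold lower number from compound 2 to compound 4 (0.24 log units; within the scatter) on this shared core, so methyl, bromo and fluoro cannot be told apart here. For the compounds shown here, the only one-place step that passes the scatter lies at another aromatic carbon, where methyl in place of hydrogen gives a 2.4-fold higher number from compound 1 to compound 4 (0.38 log units; beyond the scatter) with fluoro held fixed, a modest step in the direction of weaker inhibition of growth. No measurement is available that would explain either the flat response to the exchanged groups or the effect of the added methyl.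

The compounds shown leave open whether an amine or a methoxy group at the exchanged aromatic carbon would produce a step beyond the scatter, and whether a carboxylic acid in place of the methyl ester would change the number. They also leave open whether methyl in place of hydrogen gives a similar step when bromo, rather than fluoro, is on the ring.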